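Notes on the oxazole substituent swap in compound 3

The source may hold more compounds than are shown below. What is called first, only, known or untested is meant among the compounds shown, and "the series" means these compounds.

Within the data shown here, compound 2 `O=C(c1ncc(-c2ccccn2)o1)[C@@H]1COc2cc(Oc3ccccc3)ccc2C1` gives 27 nM in an assay for inhibition of Fatty-acid amide hydrolase 1 (Rattus norvegicus), using a Dixon plot (on this read-out lower numbers stand for stronger inhibition and higher numbers for weaker inhibition), the higher of the two numbers measured so far; its only neighbour is compound 1 `O=C(c1ncc(-c2ccccn2)o1)[C@H]1COc2cc(Oc3ccccc3)ccc2C1`, which gives 18 nM, and the step of a 1.5-fold higher number from compound 1 to compound 2 (0.18 log units; within the scatter) is the single measured step, resting on (the fact that compounds 1 and 2 differ only in the configuration as drawn). Compound 3 `O=C(c1ncc(I)o1)[C@@H]1COc2cc(Oc3ccccc3)ccc2C1` changes compound 2 at a different place: iodo in place of pyridin-2-yl on an aromatic carbon. Among the measured compounds shown here, no measured step touches the five-membered ring or its substituent, so the configuration step carries no information on this change; it shows only that the drawn configuration at the saturated ring carbon moves the number little. The expectation for compound 3 is therefore a weaker inhibition than compound 2, held with a wide range, the step being estimated as a 7.4-fold higher number from compound 2 to compound 3 (0.87 log units; beyond the scatter). Compound 3 is expected to give about 200 nM, between 40 nM and 1000 nM.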

Compound 3, inhibition constant: 31 nM
Beside the measured number, compound 3's estimate is 6.5-fold (0.81 log units) above it, outside the stated range (below it).
By their numbers in this assay, from the lowest: compounds 1, 2 and 3 (each within the scatter of the next).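

In this assay, iodo in place of pyridin-2-yl gives a 1.1-fold higher number from compound 2 to compound 3 (0.06 log units; within the scatter), so this position, on an aromatic carbon next to the ring oxygen, tolerates the loss of the whole six-membered aromatic ring with no readable shift in the number. A single iodine atom in compound 3 and the six heavy atoms of pyridin-2-yl in compound 2, with its hydrogen-bond acceptor, leave the number within the scatter, which the configuration step could not show.

From the compounds shown here alone, whether an amine, a carboxylic acid or a plain hydrogen at this position would hold the number stays open. So does whether the same swap on the core of compound 1 would behave alike.

What is known about these compounds offers no explanation for this result.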